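A few compounds are considered here, and "the series" means these few. Any claim that something is new, unique, unknown or untested is made for them only; others in the source may bear on it.

In a functional assay on A549 cells (Homo sapiens) for cytotoxicity, read by MTT assay, with a stated time of 72 h (a lower number here means a stronger inhibitor, a higher number a weaker inhibitor), compound 1 (`COc1cc2ncnc(Nc3ccc(F)c(Cl)c3)c2cc1NC(=O)N/N=C/c1ccc(F)cc1Cl`) gives 28200 nM while compound 2 (`COc1cc2ncnc(Nc3ccc(F)c(Cl)c3)c2cc1NC(=O)N/N=C/c1cccc(Cl)c1Cl`) gives 35300 nM and compound 3 (`COc1cc2ncnc(Nc3ccc(F)c(Cl)c3)c2cc1NC(=O)N/N=C/c1ccc(OC)c(OC)c1OC`) gives 32800 nM so compound 3 stands within the scatter of both others, and the three values have no meaningful order. Compound 4 (`COc1cc2ncnc(Nc3ccc(F)c(Cl)c3)c2cc1NC(=O)N/N=C/c1cc(OC)c(OC)c(OC)c1`) has the same atoms as compound 3, joined differently: 3,4,5-trimethoxyphenyl in place of 2,3,4-trimethoxyphenyl on a carbon with a double bond to nitrogen. Among the measured compounds shown here, no measured step isolates this kind of rearrangement. The closest evidence is replacement of the whole group on that carbon, where a 1.2-fold higher number from compound 1 to compound 3 (0.07 log units; within the scatter) and a 1.1-fold lower number from compound 2 to compound 3 (0.03 log units; within the scatter) and a 1.3-fold higher number from compound 1 to compound 2 (0.10 log units; within the scatter) all remain small. On that basis, no change beyond the scatter is expected in this assay and no direction can be called. The estimated step is a 1.1-fold lower number from compound 3 to compound 4 (0.04 log units; within the scatter) and it should be read as no real change. The estimate for compound 4 is 30000 nM with an expected range from 14000 nM to 60000 nM in this series.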

Compound 4, half-maximal inhibitory concentration: 32100 nM
Compound 4: middle estimate off by 1.1-fold (0.03 log units), on the low side; the range from low to high includes it.
By their numbers in this assay, from the lowest: compounds 1, 4, 3 and 2 (each within the scatter of the next).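

Rearranging the three methoxy groups, the first such change measured at this carbon with a double bond to nitrogen, gives no real change in this assay: 3,4,5-trimethoxyphenyl in place of 2,3,4-trimethoxyphenyl gives a 1.0-fold lower number from compound 3 to compound 4 (0.01 log units; within the scatter). The new group also stays within the scatter of both chlorine-bearing groups, with a 1.1-fold lower number from compound 2 to compound 4 (0.04 log units; within the scatter) and a 1.1-fold higher number from compound 1 to compound 4 (0.06 log units; within the scatter), so all four compounds now sit together, and neither the arrangement of the methoxy groups nor the exchange for halogens separates them here. No evidence is available on why these values coincide.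

The compounds shown carry only substituted phenyl groups at this carbon, so it remains open whether a dimethylamino group, a carboxylic acid or a longer alkyl chain there would move the number beyond the scatter. Also open, on these data alone, is whether changes to the shared core, rather than to this group, would shift the values.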